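A few compounds are considered here, and "the series" means these few. Any claim that something is new, unique, unknown or untested is made for them only; others in the source may bear on it.

Measured compounds:
compound 1, `COc1ccc(C2=C(c3cc(OC)c(OC)c(OC)c3)C(=O)C(OC(C)=O)C2)cc1Cl`, 24 ug/mL
compound 2, `COC(=O)c1cc(C2=C(c3cc(OC)c(OC)c(OC)c3)C(=O)CC2O[SiH2]C(C)(C)C)ccc1OC`, > 100 ug/mL

Compound 1 is `COc1ccc(C2=C(c3cc(OC)c(OC)c(OC)c3)C(=O)C(OC(C)=O)C2)cc1Cl` and in an ADME assay on MIA PaCa-2 cells (Homo sapiens) for cytotoxicity, read by MTT assay, with a stated time of 72 h (on this read-out lower numbers stand for stronger inhibition and higher numbers for weaker inhibition), compound 1 gives 24 ug/mL. Compound 2 is `COC(=O)c1cc(C2=C(c3cc(OC)c(OC)c(OC)c3)C(=O)CC2O[SiH2]C(C)(C)C)ccc1OC`. In this assay compound 2 reaches only a limit of the assay, > 100 ug/mL, as noted in the limit of > 100 ug/mL in this assay, at which 1 of the 2 values shown sits; compound 2 thus stands at the weak end of the numbers shown, with no measured number of its own.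

Compound 3, `COc1ccc(C2=C(c3cc(OC)c(OC)c(OC)c3)C(=O)CC2O[SiH2]C(C)(C)C)cc1O`, has not yet been measured. It differs from compound 2 in one place: hydroxy in place of methoxycarbonyl on an aromatic carbon.

Going by the values given here, no measured step of the same kind is known here, so the direction rests on the structures alone. The account expects the step from compound 2 to compound 3 in this assay to run toward stronger inhibition, an at least 3.3-fold lower number from compound 2 to compound 3 (0.52 log units; beyond the scatter), beyond the usual scatter. Compound 3 is therefore estimated at 30 ug/mL, within 5 ug/mL to 100 ug/mL.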

Compound 3, half-maximal inhibitory concentration: 55 ug/mL
The estimate for compound 3 lay 1.8-fold (0.26 log units) below the measured number; low and high end bracket the measured number.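

Hydroxy in place of methoxycarbonyl on the aromatic carbon ortho to a methoxy group gives, in this assay, an at least 1.8-fold lower number from compound 2 to compound 3 (0.25 log units; that floor lies within the scatter). The value of compound 2 is a limit and not a number: the limit of > 100 ug/mL in this assay, at which 1 of the 3 values shown sits. Going by these compounds alone, with hydroxy, this position now carries a measured number, which the earlier compounds did not show for it, but the floor of the step lies within the scatter, so the data show only that the true size of the change is not smaller than that floor.

The compounds shown leave open how an amine or a carboxylic acid on this same aromatic carbon would read in this assay. They also leave open whether the same change would move the number in the same direction with the acetoxy group of compound 1 on the core.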